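Ester to acid on a vitamin D receptor agonist series

The source may hold more compounds than are shown below. What is called first, only, known or untested is meant among the compounds shown, and "the series" means these compounds.

Measured compounds:
compound 1, `CCOC(=O)CN(C)C(=O)c1ccc(C(CC)(CC)c2ccc(OCC(O)C(C)(C)C)c(C)c2)n1CC`, 210 nM
compound 2, `CC[C@@H](C)[C@H](NC(=O)c1ccc(C(CC)(CC)c2ccc(OCC(=O)C(C)(C)C)c(C)c2)n1CC)C(=O)O`, 10 nM

Of the compounds shown here, two have been measured in an assay on HL-60 cells for agonist activity at vitamin D3 receptor (Homo sapiens), read by microscopy, with a stated time of 96 h; on this read-out lower numbers stand for an effect already at smaller amounts and higher numbers for an effect only at larger amounts of compound. Compound 1 gives 210 nM, which is the higher of the two numbers. Compound 2, which carries a free carboxylic acid on a branched amino-acid side chain and a ketone in place of the alcohol, gives 10 nM. Since compound 2 differs from compound 1 in more than one place, the two values alone do not tell which change is responsible for the gap between them.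

Compound 3, `CCn1c(C(=O)N(C)CC(=O)O)ccc1C(CC)(CC)c1ccc(OCC(O)C(C)(C)C)c(C)c1`, is the unmeasured compound. It keeps the shared core of compound 1 and differs from it in one place: hydrogen in place of ethyl on an oxygen next to a carbonyl group. This is the same change as opening the ester of compound 1 to a free acid.

For the measured compounds named here, no single-change step has yet been measured in this set, so the expectation for compound 3 rests on the two values alone. Given that compound 2, the only acid measured, sits well below compound 1, a modest step toward a lower number from compound 1 to compound 3 is expected, roughly a 3.5-fold lower number from compound 1 to compound 3 (0.54 log units; beyond the scatter), though a step within the scatter would not be surprising. Compound 3 is therefore estimated at 60 nM, with a likely range from 12 nM to 300 nM.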

Compound 3, half-maximal effective concentration: 740 nM
For compound 3 the middle estimate is 12-fold (1.09 log units) below the measured one, and the stated range ends below it.
By their numbers in this assay, from the lowest: compound 2; then compound 1; then compound 3.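

In this assay, for the compounds shown here, going from the ethoxycarbonyl group to carboxy gives a 3.5-fold higher number from compound 1 to compound 3 (0.55 log units; beyond the scatter), and this is the first step in the set where only one place changes. On this core, then, the ethyl ester has the lower number of the pair, and a free acid at this place does not by itself lower the number, whatever the acid in compound 2 seemed to suggest; compound 2 differs from compound 3 in more than one place, so it cannot settle the effect of the acid alone. Nothing measured here explains why the step runs in this direction.

Still open, from the compounds shown here alone, is whether a methyl ester, a longer chain on the same oxygen, or a primary amide in place of the ethoxycarbonyl group would give a lower number than compound 1 does. Going by these compounds alone, also open is how much of the low number of compound 2 belongs to its ketone and how much to its branched amino-acid side chain: no single-change step separates the two.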